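Adding a 2-chlorophenyl group to a core at the limit

A few compounds are considered here, and "the series" means these few. Any claim that something is new, unique, unknown or untested is made for them only; others in the source may bear on it.

Measured compounds:
compound 1 `O=S(=O)(Nc1ccc(F)c(C#Cc2cnc3[nH]ncc3c2)c1F)c1ccccc1`: > 10000 nM
compound 2 `O=S(=O)(Nc1ccc(F)c(C#Cc2cnc3[nH]ncc3c2)c1F)c1ccccc1F`: > 10000 nM
compound 3 `O=S(=O)(Nc1ccc(F)c(C#Cc2cnc3[nH]ncc3c2)c1F)c1cccnc1`: > 10000 nM

In a functional assay on HCT-116 cells (Homo sapiens) for antiproliferative activity, read by MTT assay, with a stated time of 68 h (on this read-out higher numbers stand for weaker inhibition and lower numbers for stronger inhibition), compound 3 gives > 10000 nM, which is a limit of the assay and not a number. Compound 1 and compound 2 also stand at a limit, so that (the limit of > 10000 nM in this assay, at which 3 of the 3 values shown sit). Accordingly the steps a step that the two limits leave unreadable from compound 1 to compound 2, a step that the two limits leave unreadable from compound 1 to compound 3 and a step that the two limits leave unreadable from compound 2 to compound 3 cannot be read in size or direction.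

Compound 4 `O=S(=O)(Nc1ccc(F)c(C#Cc2cnc3[nH]nc(-c4ccccc4Cl)c3c2)c1F)c1cccnc1` differs from compound 3 in one place: 2-chlorophenyl in place of hydrogen on an aromatic carbon. Among the compounds with values here, none of the measured steps touches this part of the core, so no measured step bears on the change, and its size cannot be read from the values shown. On that footing compound 4 is expected to give about 5000 nM, estimated between 500 nM and 20000 nM. The step of an at least 2.0-fold lower number from compound 3 to compound 4 (0.30 log units; that floor lies within the scatter) that this estimate implies is therefore an expectation carrying wide uncertainty.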

Compound 4, half-maximal inhibitory concentration: > 10000 nM
Compound 4 gave a limit, no number (the forecaster's own chance of this, stated with the estimate: 45%); at least 2.0-fold (0.30 log units) between middle value and limit.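

Compound 4, at > 10000 nM as a limit and not a number, leaves the change from compound 3 to compound 4 unreadable. The compounds shown leave open how large the effect of 2-chlorophenyl in place of hydrogen is, and its direction.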